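Adding one chloro group to compound 3

A few compounds are considered here, and "the series" means these few. Any claim that something is new, unique, unknown or untested is made for them only; others in the source may bear on it.

Compound 1 `O=C(Nc1cccc(-n2cc(-c3ccncc3)c(-c3ccc(Cl)c(O)c3)n2)c1)Nc1cccc(C(F)(F)F)c1`: > 32500 nM (a limit)
Compound 2 `COc1cc(-c2nn(-c3cccc(NC(=O)Nc4cc(C(F)(F)F)cc(C(F)(F)F)c4)c3)cc2-c2ccncc2)ccc1Cl`: 4480 nM
Compound 3 `COc1cc(-c2nn(-c3cccc(NC(=O)c4cccc(C(F)(F)F)c4)c3)cc2-c2ccncc2)ccc1Cl`: > 50000 nM (a limit)

The read-out in a functional assay on MOLT-4 cells (Homo sapiens) for inhibition, read by sulforhodamine B assay, with a stated time of 48 h (a higher number here means a weaker inhibitor of growth, a lower number a stronger inhibitor of growth), is the concentration needed for total growth inhibition. Compound 3 has no exact number, only a limit of > 50000 nM. Compound 1 also has only a limit, > 32500 nM. Compound 2 is the only one of the three with an exact number, 4480 nM, which shows that this assay can return a number for a compound of this series.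

Compound 4 `COc1cc(-c2nn(-c3cccc(NC(=O)c4ccc(Cl)c(C(F)(F)F)c4)c3)cc2-c2ccncc2)ccc1Cl` is compound 3 with a single change: chloro in place of hydrogen on an aromatic carbon. A chloro takes the place of a hydrogen on an aromatic carbon, ortho to a trifluoromethyl group and para to a large group. This turns 3-(trifluoromethyl)phenyl into 4-chloro-3-(trifluoromethyl)phenyl.

Going by the values given here, no two measured compounds differ in just one place, so there is no direct guide to the size of this step. A modest move towards a lower number is expected in this assay, although another limit would be no surprise. The expected step is an at least 2.7-fold lower number from compound 3 to compound 4 (0.44 log units; beyond the scatter), and its size is rough. For compound 4 the estimated value is 18000 nM, with an expected range of 5000 nM to 50000 nM.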

Compound 4, concentration for total growth inhibition: > 32500 nM
Compound 4: a limit, no number; the forecaster's own chance of this, stated with the estimate: 45%; middle value at least 1.8-fold (0.25 log units) away from the limit.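

In this assay, going by these compounds alone, compound 4 gives only a limit (> 32500 nM), and compound 3 also has only a limit, so no step between compound 3 and compound 4 can be read. The compounds shown leave open whether chloro in place of hydrogen on this aromatic carbon changes total growth inhibition at all, in either direction.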